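Swapping Hydroxy for Amino on Two Stilbene Scaffolds

The compounds below may be only part of what the source reports. "The series", "measured", "known", "first", "only" and "open" are said of these compounds alone.

Compound 1 `Oc1cccc(/C=C/c2cccc(O)c2)c1` and compound 2 `COc1ccccc1/C=C/c1ccccc1O` both carry two hydroxy-type substituents around a shared stilbene-like framework; how the two cores differ is not broken down here. In an ADME assay on HEK293 cells (Homo sapiens) for inhibition, read by MTT assay, with a stated time of 2 days (on this read-out higher numbers stand for weaker inhibition and lower numbers for stronger inhibition), compound 1 gives 21 ug/mL. In this assay compound 2 gives 15 ug/mL, a value within the usual scatter of that of compound 1. Compound 3 `Nc1cccc(/C=C/c2cccc(O)c2)c1` arises from compound 1 through the change (amino in place of hydroxy on an aromatic carbon). For compound 3 this assay reports only a limit, > 100 ug/mL, as noted in the limit of > 100 ug/mL in this assay, at which 1 of the 3 values shown sits. That change produced a step of an at least 4.7-fold higher number from compound 1 to compound 3 (0.67 log units; beyond the scatter).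

Compound 4 `COc1ccccc1/C=C/c1ccccc1N`, not yet measured, is related to compound 2 by the change (amino in place of hydroxy on an aromatic carbon). This is the same kind of change as that from compound 1 to compound 3, though its place differs: it sits ortho to a large group, whereas the earlier one sat meta to a group of 9 heavy atoms. Resting on the step from compound 1 to compound 3, a comparable weakening is expected, a 4.0-fold higher number from compound 2 to compound 4 (0.60 log units; beyond the scatter). Compound 4 is therefore estimated at 60 ug/mL, with a range from 25 ug/mL to 150 ug/mL.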

Compound 4, half-maximal inhibitory concentration: 2.1 ug/mL
Compound 4: middle estimate off by 29-fold (1.46 log units), on the high side; the measured number lies below the stated range.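

On the second core the same swap gave a 7.1-fold lower number from compound 2 to compound 4 (0.85 log units; beyond the scatter) in this assay, opposite in direction to the earlier step, and the two steps differ: the same change on two cores in this assay, an at least 4.7-fold higher number (0.67 log units; beyond the scatter) from compound 1 to compound 3 and a 7.1-fold lower number (0.85 log units; beyond the scatter) from compound 2 to compound 4, at least 34-fold (1.53 log units) apart, beyond the scatter of two such steps. The earlier step has no exact endpoint, since the value for compound 3 is a limit: the limit of > 100 ug/mL in this assay, at which 1 of the 4 values shown sits. This shows that, in this series, the step seen on the core of compound 1 did not carry over to the core of compound 2, but with one pair per core and the change sitting at a different place in each, it does not show whether the core or the place accounts for the reversal.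

The compounds shown leave open whether a dimethylamino group or an acetamide at the same place would follow compound 4 or compound 3. They also leave open which way the swap would go on any third core, and whether the reversal holds in any read-out other than this assay.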